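The compounds below may be only part of what the source reports. "The series", "measured", "known", "first", "only" and "open" are said of these compounds alone.

Measured so far:
compound 1 `CC(=O)CC1Oc2cc(O)ccc2C=C1c1ccc(O)cc1`: 145000 nM
compound 2 `CC(C)CC(=O)CC1Oc2cc(O)ccc2C=C1c1ccc(O)cc1`: 67000 nM
compound 3 `O=C(CC1Oc2cc(O)ccc2C=C1c1ccc(O)cc1)c1ccc(Cl)cc1`: 151000 nM

All three values come from a functional assay on MDA-MB-231 cells (Homo sapiens) for antiproliferative activity, read by spectrophotometry and resazurin assay, with a stated time of 72 h (on this read-out higher numbers stand for weaker inhibition and lower numbers for stronger inhibition), where compound 2 has the lowest number, with both of its steps to the other two beyond the scatter. Compound 4 `Cc1cc(C2Oc3cc(O)ccc3C=C2c2ccc(O)cc2)cc(C)c1N` is the next case: 4-amino-3,5-dimethylphenyl in place of (isobutylcarbonyl)methyl on a saturated ring carbon. In words, this is 4-amino-3,5-dimethylphenyl in place of (isobutylcarbonyl)methyl on a saturated ring carbon.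

Among the compounds with values here, no measured step makes this change. All three keep the carbonyl and vary only the group it carries, so they bear on it only indirectly. They are small: a 2.2-fold lower number from compound 1 to compound 2 (0.34 log units; beyond the scatter) and a 2.3-fold higher number from compound 2 to compound 3 (0.35 log units; beyond the scatter) are both modest, and a 1.0-fold higher number from compound 1 to compound 3 (0.02 log units; within the scatter) stays within the scatter. Even the aromatic 4-chlorophenyl group of compound 3 gave only a modest shift from compound 2. Within the data shown here, the data contain no compound with an aryl group directly on the saturated ring carbon, so the direction is poorly supported. A small step in this assay is therefore expected, probably within the scatter, with a slight lean towards a lower number held only loosely. The estimate corresponds to a 1.3-fold lower number from compound 2 to compound 4 (0.13 log units; within the scatter). For compound 4 the expected value is 50000 nM, with an estimated range of 12000 nM to 150000 nM.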

Compound 4, half-maximal inhibitory concentration: 53000 nM
For compound 4 the middle estimate is 1.1-fold (0.03 log units) below the measured one; low and high end bracket the measured number.
By their numbers in this assay, from the lowest: compounds 4 and 2 (each within the scatter of the next); then compounds 1 and 3 (each within the scatter of the next).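

In this assay, the saturated ring carbon next to the ring oxygen accepts a directly attached 4-amino-3,5-dimethylphenyl in place of the whole (isobutylcarbonyl)methyl group, with a 1.3-fold lower number from compound 2 to compound 4 (0.10 log units; within the scatter). Among the compounds shown, a carbonyl in this substituent is therefore not needed to keep the number at this level, and a six-membered aromatic ring can stand directly on this carbon. Set against the smaller 2-oxopropyl group, the same change gives a 2.7-fold lower number from compound 1 to compound 4 (0.44 log units; beyond the scatter), so the outcome depends on which group leaves, though this step is only modest, and no measurement at hand accounts for either step.

As far as these compounds go, it remains open how a plain phenyl or a 4-hydroxyphenyl group on this carbon would compare, which would separate the contribution of the aromatic ring itself from that of its amino and two methyl groups. Also open, from the compounds shown here alone, is whether a longer chain or a carboxylic acid in this position would shift the number further than the modest steps seen so far.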